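From compound 1 to compound 3: an aryl exchange

This account rests on a few compounds, and the source may have more. Where it says the series, first, only, none or still open, it means among the compounds named here.

Measured compounds:
compound 1, `COC1=C(C)C(=O)/C(=C(O)/C=C/c2ccc(Br)cc2)C(=O)C1(C)C`: 17.7 ug/mL
compound 2, `COC1=C(C)C(=O)/C(=C(O)/C=C/c2cccc(OC)c2)C(=O)C1(C)C`: 14.3 ug/mL

In a functional assay on PC-3 cells (Homo sapiens) for cytotoxicity (on this read-out higher numbers stand for an effect only at larger amounts of compound and lower numbers for an effect already at smaller amounts), compound 1 gives 17.7 ug/mL, the highest of the two numbers in hand, and compound 2 gives 14.3 ug/mL, which lies within the scatter of compound 1 in this assay. Compound 3, `COC1=C(C)C(=O)/C(=C(O)/C=C/c2c(C)cccc2C)C(=O)C1(C)C`, is not yet measured. It differs from compound 1 in one place: 2,6-dimethylphenyl in place of 4-bromophenyl on a double-bonded chain carbon bound to a double-bonded chain carbon. For the measured compounds named here, the only measured step that bears on this change is the one from compound 1 to compound 2, where a 1.2-fold lower number from compound 1 to compound 2 (0.09 log units; within the scatter). That step replaced the same 4-bromophenyl by another substituted six-membered aromatic ring of carbon only and left this assay unchanged beyond the scatter; 2,6-dimethylphenyl has not been tested, so its effect rests on this single comparison alone. A step from compound 1 to compound 3 of no more than the scatter is therefore expected, in no preferred direction, as a 1.1-fold lower number from compound 1 to compound 3 (0.04 log units; within the scatter). For compound 3 in this assay a value of 16 ug/mL is estimated, with a range of 8 ug/mL to 32 ug/mL.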

Compound 3, concentration for half-maximal effect: 17.1 ug/mL
For compound 3 the middle estimate is 1.1-fold (0.03 log units) below the measured one; the range from low to high includes it.
By their numbers in this assay, from the lowest: compounds 2, 3 and 1 (each within the scatter of the next).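

In this assay, putting 2,6-dimethylphenyl in place of 4-bromophenyl on a double-bonded chain carbon bound to a double-bonded chain carbon gives a 1.0-fold lower number from compound 1 to compound 3 (0.01 log units; within the scatter) and putting it in place of 3-methoxyphenyl gives a 1.2-fold higher number from compound 2 to compound 3 (0.08 log units; within the scatter) in the same assay. Three substituted six-membered aromatic rings of carbon only now stand at this place, carrying bromine, methoxy and two methyl groups, and all three compounds lie within the scatter of one another, where the earlier pair offered a single comparison. The result extends that picture to a ring with two substituents and with no bromine or oxygen, though it holds only for these three compounds, and nothing measured alongside these values explains it.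

The compounds shown leave open whether a group of another kind at this place, such as an amine, a carboxylic acid or a longer chain on the ring, would move the number beyond the scatter. They also leave open how an unsubstituted phenyl ring, or a pyridine ring with nitrogen among its ring atoms, would compare with these three.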